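The source may report more compounds than this note shows. Statements on the series, on what has been measured and on what is new or still open speak of the compounds shown alone.

Of the compounds shown here, two have so far been measured in an ADME assay on BV-2 cells (Mus musculus) for cytotoxicity, with a stated time of 24 h, tested at 10 uM; on this read-out lower numbers stand for a stronger effect and higher numbers for a weaker effect at the one concentration tested. Compound 1, `COc1ccc(S(=O)(=O)/C=C/c2cccnc2)cc1`, gives 99.5% in this assay. Compound 2, `COc1ccccc1/C=C/S(=O)(=O)c1ccccn1`, gives 100% in this assay. The number of compound 2 and the number of compound 1 lie within the usual scatter of one another, so both show the same weak effect at the single concentration tested, and no ordering between them can be claimed.

Compound 3, `O=S(=O)(/C=C/c1ccccc1F)c1ccccn1`, has not been measured yet. It differs from compound 2 in one place: fluoro in place of methoxy on an aromatic carbon. The change sits on an aromatic carbon of a six-membered aromatic ring of carbon only, ortho to a large group. Within the data shown here, no pair of measured compounds shows this change, so nothing seen here points to a shift beyond the scatter in this assay. For this change the expected step is a number 2 percentage points lower from compound 2 to compound 3 (within the scatter), none beyond the scatter. Compound 3 is estimated at 98% in this assay, within a range from 88% to 105%.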

Compound 3, a percentage reported as activity, at one concentration (the size of the read-out at that concentration, not a potency): 100%
Estimate against measurement, compound 3: 2 percentage points below; the measured number falls inside the stated range.
By their numbers in this assay, from the lowest: compounds 1, 2 and 3 (each within the scatter of the next).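

In this assay, fluoro in place of methoxy on this aromatic carbon, ortho to a large group, gives no change at the digits printed from compound 2 to compound 3 (within the scatter) for this pair. So at this one place, the methoxy group, with its oxygen and its hydrogen-bond acceptor, can give way to a single fluorine atom without the weak effect at the one concentration tested growing beyond the scatter. Nothing measured here explains why this swap leaves the read-out as it is.

The compounds shown leave open whether an amine or a carboxylic acid on this same aromatic carbon would also leave the number within the scatter. They also leave open whether fluoro would behave the same way on another carbon of this ring, or whether any of these compounds would show a stronger effect at a higher concentration.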